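Swapping a Methyl for Fluoro on a Pyridine Arm

The compounds below may be only part of what the source reports. "The series", "measured", "known", "first", "only" and "open" are said of these compounds alone.

Three close relatives of one shared core have been tested in an ADME assay on the whole organism for pharmacokinetics, with Rattus norvegicus as the target, with a stated time of 6 h, at a dose of 10 mg/kg by the oral route; on this read-out higher numbers stand for higher exposure at the dose given and lower numbers for lower exposure. Compound 1 `Cc1cn2c(-c3cn[nH]c3)cnc2c(Nc2cc(Cc3nccs3)ns2)n1` gives 1540 ng.h/mL. Compound 2 `Cc1cn2c(-c3cn[nH]c3)cnc2c(Nc2cc(Cc3ccccn3)ns2)n1` gives 6880 ng.h/mL, and compound 3 `Cc1cccc(Cc2cc(Nc3nc(C)cn4c(-c5cn[nH]c5)cnc34)sn2)n1` gives 3100 ng.h/mL. On these numbers compound 3 stands second highest of the three: its gap to compound 1 is within the scatter, while its gap to compound 2 is beyond it. The measured steps are a 4.5-fold higher number from compound 1 to compound 2 (0.65 log units; beyond the scatter), a 2.0-fold higher number from compound 1 to compound 3 (0.30 log units; within the scatter) and a 2.2-fold lower number from compound 2 to compound 3 (0.35 log units; beyond the scatter).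

Compound 4 `Cc1cn2c(-c3cn[nH]c3)cnc2c(Nc2cc(Cc3cccc(F)n3)ns2)n1` differs from compound 3 in one place: fluoro in place of methyl on an aromatic carbon. The step that bears most directly on this change is a 2.2-fold lower number from compound 2 to compound 3 (0.35 log units; beyond the scatter), which shows the methyl lowering exposure relative to a hydrogen in the same spot. Fluoro, like hydrogen, is counted as a single heavy atom there, so taking the methyl away is expected to move the number part of the way back toward compound 2, though nothing measured here pins down how far. The expected step is therefore a 1.5-fold higher number from compound 3 to compound 4 (0.16 log units; within the scatter), a small rise that may well sit within the scatter. Compound 4 is estimated at 4500 ng.h/mL, with a range from 1800 ng.h/mL to 11000 ng.h/mL.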

Compound 4, area under the concentration-time curve: 2970 ng.h/mL
Compound 4: the middle estimate sits 1.5-fold (0.18 log units) above what was measured; measured number inside the range.
By their numbers in this assay, from the lowest: compounds 1, 4 and 3 (each within the scatter of the next); then compound 2.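

In this assay, swapping the methyl for fluoro next to the ring nitrogen makes no readable difference (a 1.0-fold lower number from compound 3 to compound 4 (0.02 log units; within the scatter)), so at this spot the two groups cannot be told apart. The fluoro compound also reads beyond the scatter against the bare pyridin-2-yl arm (a 2.3-fold lower number from compound 2 to compound 4 (0.36 log units; beyond the scatter)), much as the methyl compound did (a 2.2-fold lower number from compound 2 to compound 3 (0.35 log units; beyond the scatter)), so in these two cases the loss relative to hydrogen is not peculiar to the methyl. The 6-fluoropyridin-2-yl arm also cannot be separated from the 1,3-thiazol-2-yl arm (a 1.9-fold higher number from compound 1 to compound 4 (0.29 log units; within the scatter)), which leaves the unsubstituted pyridin-2-yl arm of compound 2 alone at the top of this small set.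

With only methyl and fluoro at this spot, the compounds shown leave open whether other groups there, such as a methoxy, a chloro or an amine, would read like these two or come back toward hydrogen. Why either group reads lower than hydrogen also stays open, as no measurement shown here speaks to the reason.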